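The source may report more compounds than this note shows. Statements on the series, on what has been measured and on what is new or still open speak of the compounds shown alone.

Working notes on the series in a functional assay on A549 cells (Homo sapiens) for antiproliferative activity, read by MTT assay, with a stated time of 48 h; a lower number here means a stronger inhibitor, a higher number a weaker inhibitor. Compound 1 `O=C(/C=C/c1ccc(O)c(O)c1)N1CCN(c2ccccc2Cl)CC1` gives 1.44 ug/mL, compound 2 `COc1ccccc1N1CCN(C(=O)/C=C/c2ccc(O)c(O)c2)CC1` gives 0.98 ug/mL and compound 3 `Cc1ccc(N2CCN(C(=O)/C=C/c3ccc(O)c(O)c3)CC2)c(C)c1` gives 1.02 ug/mL, so compound 3 stands within the scatter of both others. Compound 4 `O=C(/C=C/c1ccc(O)c(O)c1)N1CCN(c2ccc(Cl)c(Cl)c2)CC1` carries 3,4-dichlorophenyl in place of 2,4-dimethylphenyl on an amine nitrogen in a ring. The measured steps that bear on this are a 1.4-fold lower number from compound 1 to compound 3 (0.15 log units; within the scatter), a 1.0-fold higher number from compound 2 to compound 3 (0.02 log units; within the scatter) and a 1.5-fold lower number from compound 1 to compound 2 (0.17 log units; within the scatter), and all stay within the scatter. For the measured compounds named here, no measured compound carries 3,4-dichlorophenyl, so the basis is thin. No step beyond the scatter is expected in this assay. The estimated change is a 1.2-fold higher number from compound 3 to compound 4 (0.07 log units; within the scatter). Compound 4 is expected at 1.2 ug/mL, with an estimated range of 0.6 ug/mL to 2.6 ug/mL.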

Compound 4, half-maximal inhibitory concentration: 1.74 ug/mL
The estimate for compound 4 lay 1.5-fold (0.16 log units) below the measured number; measured number inside the range.
By their numbers in this assay, from the lowest: compounds 2, 3, 1 and 4 (each within the scatter of the next).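

Set against the earlier aryl groups on the amine nitrogen in a ring, 3,4-dichlorophenyl gives a 1.7-fold higher number from compound 3 to compound 4 (0.23 log units; within the scatter), a 1.8-fold higher number from compound 2 to compound 4 (0.25 log units; within the scatter) and a 1.2-fold higher number from compound 1 to compound 4 (0.08 log units; within the scatter). For the compounds shown here, a phenyl group carrying two chlorine atoms therefore fits the same narrow band as the earlier compounds, and all four compounds at this position remain within the scatter of one another, with no order among them. No measurement is available to explain these small differences. Going by these compounds, it remains open whether a phenyl group carrying an amine or a carboxylic acid, or a longer alkyl chain in place of the phenyl group, would produce a step beyond the scatter.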